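Removing the Cyclopentyl Group from Compound 2

This account rests on a few compounds, and the source may have more. Where it says the series, first, only, none or still open, it means among the compounds named here.

Compound 1 `COc1ccc(-c2noc(C3CCCN3)n2)cc1OC1CCCC1`: 43 nM
Compound 2 `COc1ccc(-c2noc(-c3ccc(F)cc3)n2)cc1OC1CCCC1`: 87900 nM

In a functional assay on LNCaP cells (Homo sapiens) for antiproliferative activity, read by MTT assay, with a stated time of 24 h (a lower number here means a stronger inhibitor, a higher number a weaker inhibitor), compound 2 gives 87900 nM, the highest of the two numbers. For the measured compounds named here, the only measured step, a 2000-fold higher number from compound 1 to compound 2 (3.31 log units; beyond the scatter), is large, but it replaces a different group and says nothing direct about the change considered here. Compound 3 `COc1ccc(-c2noc(-c3ccc(F)cc3)n2)cc1O` differs from compound 2 at one place: hydrogen in place of cyclopentyl on an oxygen on an aromatic ring. Going by the values given here, no measured step involves this group, so the data show neither the size nor the direction of its effect. With nothing to indicate otherwise, no shift beyond the scatter is expected, and the expectation stays anchored on compound 2 at 87900 nM. The estimated change is a 1.5-fold lower number from compound 2 to compound 3 (0.17 log units; within the scatter). Compound 3 is expected at 60000 nM, with an estimated range of 15000 nM to 200000 nM.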

Compound 3, half-maximal inhibitory concentration: > 1000000 nM
Compound 3: no number, only a limit; the forecaster's own chance of this, stated with the estimate: 25%; middle value at least 16-fold (1.22 log units) away from the limit.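

In this assay, the earlier step showed only what happens when a different group is changed, and it said nothing about the oxygen on the aromatic ring. Here, hydrogen in place of cyclopentyl at that oxygen gives an at least 11-fold higher number from compound 2 to compound 3 (1.05 log units; beyond the scatter), so this position responds to the change even though compound 2 is already weak at 87900 nM. Compound 3 carries a limit rather than a number, so the step gives only a minimum size: the limit of > 1000000 nM in this assay, at which 1 of the 3 values shown sits.

The compounds shown leave open how large the step really is, and whether cyclopentyloxy to hydroxy would matter to the same extent with the pyrrolidin-2-yl group of compound 1. They also leave open whether a methyl, a cyclohexyl or a longer chain on this oxygen would keep or lose the activity.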